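This account rests on a few compounds, and the source may have more. Where it says the series, first, only, none or still open, it means among the compounds named here.

Of the compounds shown here, three sharing one core have so far been measured in an assay on mitochondria (strain BALB/c) for inhibition of glycerol-3-phosphate acyltransferase 1, mitochondrial (Mus musculus), read by scintillation counting, with a stated time of 10 min; a higher number here means a weaker inhibitor, a lower number a stronger inhibitor. Compound 1 `CCCCCCCCS(=O)(=O)Nc1ccc(-c2ccccc2Cl)cc1C(=O)O` gives 14400 nM in this assay. Compound 2 `CCCCCCCCS(=O)(=O)Nc1ccc(-c2cccc(Cl)c2)cc1C(=O)O` gives 8900 nM. Within the data shown here, the only single-point step among the measured set, a 1.6-fold lower number from compound 1 to compound 2 (0.21 log units; within the scatter), stays within the scatter. Compound 3 `CCCCCCCCS(=O)(=O)Nc1ccc(C(=O)c2ccc(CCCC)cc2)cc1C(=O)O` gives 31700 nM, the highest of the three numbers; its gap to compound 1 and its larger gap to compound 2 both lie beyond the scatter, so on these numbers compound 3 is the weakest inhibitor of the three.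

Compound 4 `CCCCCCCCS(=O)(=O)Nc1ccc(C(=O)c2ccccc2OC)cc1C(=O)O` has not yet been measured. It differs from compound 3 in one place: 2-methoxyphenyl in place of 4-butylphenyl on a carbonyl carbon. Among the measured compounds shown here, no measured step exchanges a group on a carbonyl carbon, so nothing measured bears on this change directly. For the measured compounds named here, the one step at hand, a 1.6-fold lower number from compound 1 to compound 2 (0.21 log units; within the scatter), moves a chlorine on a directly attached aryl ring and stays within the scatter, which offers only loose guidance here. On that basis no movement beyond the scatter is expected, and the step anticipated is a 1.1-fold lower number from compound 3 to compound 4 (0.02 log units; within the scatter). Compound 4 is therefore estimated to give 30000 nM in this assay, with a range from 10000 nM to 90000 nM.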

Compound 4, half-maximal inhibitory concentration: 59200 nM
Compound 4: middle estimate off by 2.0-fold (0.30 log units), on the low side; the range from low to high includes it.
By their numbers in this assay, from the lowest: compounds 2 and 1 (each within the scatter of the next); then compounds 3 and 4 (each within the scatter of the next).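

In this assay, a 1.9-fold higher number from compound 3 to compound 4 (0.27 log units; within the scatter) stays within the scatter, so on the carbonyl carbon 2-methoxyphenyl cannot be told apart from 4-butylphenyl, even though the entering group has fewer heavy atoms and brings a hydrogen-bond acceptor that the leaving group lacks. Among these compounds, compound 4 also gives the first single-place comparisons between the carbonyl-linked aryl compounds and the chlorophenyl compounds: a 6.7-fold higher number from compound 2 to compound 4 (0.82 log units; beyond the scatter) and a 4.1-fold higher number from compound 1 to compound 4 (0.61 log units; beyond the scatter) both lie beyond the scatter, though both are modest, so replacing either chlorophenyl with (2-methoxyphenyl)carbonyl on this aromatic carbon gives a weaker inhibitor. Nothing available explains either the flat step on the carbonyl carbon or the two larger steps on the aromatic carbon.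

These compounds leave open whether the higher numbers belong to the carbonyl link itself, since no chlorophenyl on a carbonyl carbon stands among them to separate the link from the change of ring substituent. They also leave open whether a phenyl ring carrying an amine or a carboxylic acid on the carbonyl carbon would move the number beyond the scatter, as the two groups compared here do not.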